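Exchanging Iodo for 1-Benzofuran-2-yl on a Nucleoside Core

The source may hold more compounds than are shown below. What is called first, only, known or untested is meant among the compounds shown, and "the series" means these compounds.

Within the data shown here, in an ADME assay on MRC5 cells (Homo sapiens), read by MTT assay, with a stated time of 72 h (a higher number here means a weaker inhibitor, a lower number a stronger inhibitor), compound 3 `COc1ncnc2c1c(I)cn2[C@@H]1O[C@H](CO)[C@@H](O)[C@H]1O` gives 63000 nM, the lowest of the three numbers so far, though both neighbours stay within the scatter of it: compound 1 `COc1ncnc2c1c(-c1ccsc1)cn2[C@@H]1O[C@H](CO)[C@@H](O)[C@H]1O` gives 75300 nM, and compound 2 `Cc1ncnc2c1c(-c1cc3ccccc3o1)cn2[C@@H]1O[C@H](CO)[C@@H](O)[C@H]1O` gives 84400 nM. Among the measured compounds shown here, the only measured step that involves compound 3 is a 1.2-fold lower number from compound 1 to compound 3 (0.08 log units; within the scatter), a swap of an aromatic group for a halogen on the same carbon that left the read-out unmoved.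

Compound 4 `COc1ncnc2c1c(-c1cc3ccccc3o1)cn2[C@@H]1O[C@H](CO)[C@@H](O)[C@H]1O` differs from compound 3 in a single place: 1-benzofuran-2-yl in place of iodo on an aromatic carbon. For the measured compounds named here, the one step bearing on such an exchange, a 1.2-fold lower number from compound 1 to compound 3 (0.08 log units; within the scatter), was within the scatter, and compound 2, which already carries the 1-benzofuran-2-yl group, shows 84400 nM, a number in the same region. With no measured change beyond the scatter among these compounds, no step beyond the scatter is expected in this assay.

Compound 4 is therefore estimated at about 80000 nM, with a range from 40000 nM to 160000 nM. For compound 4 the expected step is a 1.3-fold higher number from compound 3 to compound 4 (0.10 log units; within the scatter), anticipated to remain within the scatter.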

Compound 4, half-maximal inhibitory concentration: 65600 nM
The estimate for compound 4 lay 1.2-fold (0.09 log units) above the measured number; measured number inside the range.
By their numbers in this assay, from the lowest: compounds 3, 4, 1 and 2 (each within the scatter of the next).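

At this aromatic carbon of the five-membered ring, the exchange of iodo, a single heavy atom, for 1-benzofuran-2-yl, with 9 heavy atoms and two aromatic rings, makes no measurable difference in this assay (a 1.0-fold higher number from compound 3 to compound 4 (0.02 log units; within the scatter)). Exchanging thiophen-3-yl for 1-benzofuran-2-yl on the same carbon also stays within the scatter (a 1.1-fold lower number from compound 1 to compound 4 (0.06 log units; within the scatter)), so this position now has a halogen and two different aromatic groups measured on the same methoxy-bearing core, and none of the three separates from the others. Among these compounds, the result also adds the first reading of a change at a second place, methoxy in place of methyl with 1-benzofuran-2-yl held constant, and that too remains within the scatter (a 1.3-fold lower number from compound 2 to compound 4 (0.11 log units; within the scatter)).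

Nothing among the data shown accounts for this flat picture. Still open, from the compounds shown here alone, is whether an amine or a carboxylic acid on this aromatic carbon, or a longer chain in place of the methoxy group, would produce a step beyond the scatter in this assay.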